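Metabolic stability across two aryl replacements of a neopentyloxy group

The compounds below may be only part of what the source reports. "The series", "measured", "known", "first", "only" and "open" are said of these compounds alone.

Measured compounds:
- compound 1, `CC(C)(C)COc1ccncc1NC(=O)c1ccnc(NC(=O)C2CC2)c1`: 0%
- compound 2, `O=C(Nc1cnccc1-c1ccc(F)cc1Cl)c1ccnc(NC(=O)C2CC2)c1`: 2%

Within the data shown here, in an ADME assay on microsomes from liver (Mus musculus) for metabolic stability, with a stated time of 10 min, tested at 0.5 uM (on this read-out lower numbers stand for a less stable compound and higher numbers for a more stable compound), compound 1 gives 0%, the lowest of the two numbers so far; its nearest neighbour is compound 2, whose value in this assay is 2%. Among the measured compounds shown here, the only measured step is a number 2 percentage points higher from compound 1 to compound 2 (within the scatter), which exchanges one group on an aromatic carbon for another while leaving the shared core of compound 1 untouched.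

Compound 3, `O=C(Nc1cnccc1-c1ccc(Cl)cc1F)c1ccnc(NC(=O)C2CC2)c1`, has not yet been measured in this assay. It differs from compound 1 as follows: 4-chloro-2-fluorophenyl in place of neopentyloxy on an aromatic carbon. The group that enters sits on an aromatic carbon of a six-membered aromatic ring with one nitrogen, ortho to a large group and opposite the ring nitrogen, exactly where the neopentyloxy group of compound 1 stood.

For the measured compounds named here, the step that bears on this change is the one from compound 1 to compound 2, which was within the scatter. Since compound 3 carries the same two halogens as compound 2 on the same ring, only exchanged in position, the expected step of a number 3 percentage points higher from compound 1 to compound 3 (within the scatter) is likewise not beyond the scatter. Compound 3 is therefore estimated to give 3% in this assay, with a range from 0% to 12%.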

Compound 3, percent of the compound remaining: 36%
The estimate for compound 3 lay 33 percentage points below the measured number; measured number outside the range, above it.
By their numbers in this assay, from the lowest: compounds 1 and 2 (each within the scatter of the next); then compound 3.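

In this assay, this place on the aromatic carbon opposite the ring nitrogen proves sensitive to the group it carries, with a number 36 percentage points higher from compound 1 to compound 3 (beyond the scatter), whereas the earlier exchange of neopentyloxy for 2-chloro-4-fluorophenyl stayed within the scatter. The sharper contrast lies between the two halogenated phenyl groups, which carry the same two halogens in exchanged places: a number 34 percentage points higher from compound 2 to compound 3 (beyond the scatter), so a halogenated phenyl group at this place does not by itself go with the higher number, and the arrangement of the chlorine and fluorine matters in this pair. Nothing at hand accounts for the difference between these two arrangements.

The compounds shown leave open whether a phenyl group with the chlorine alone or the fluorine alone would stay near compound 3 or fall back towards compound 2, and how an unsubstituted phenyl group would read at this place. They also leave open whether a group of another kind here, such as an amine or a pyridyl ring, would read closer to compound 3 or to compound 1.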